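Working notes: compound 2 to compound 3

The source may report more compounds than this note shows. Statements on the series, on what has been measured and on what is new or still open speak of the compounds shown alone.

- compound 1 `CC(C)OC(=O)OCOC(=O)c1ccc(N)cc1O` gives 0%
- compound 2 `CC(OC(=O)c1ccc(N)cc1O)OC(=O)C(C)(C)C` gives 0%

Both values come from an ADME assay on a cell-free system (plasma, Homo sapiens) for metabolic stability, read by LC-MS, with a stated time of 2 h, tested at 1 ug/mL (a higher number here means that more of the compound is left, a lower number that less of the compound is left), and compound 2 stands level with compound 1 there, with no difference at the digits reported. Compound 3 `CC(C)OC(=O)OC(C)OC(=O)c1ccc(N)cc1O` has not yet been measured. Against compound 2 the change is isopropoxy in place of tert-butyl on a carbonyl carbon and it puts isopropoxy in place of tert-butyl on a carbonyl carbon. For the measured compounds named here, no measured pair differs in one place only, so the data offer no direct guide to this change. In this assay no step beyond the scatter is expected, because compound 2 shows 0% and the read-out has no room to fall further. The expected no change at the digits printed from compound 2 to compound 3 (within the scatter) stays within the scatter. The estimated value for compound 3 is 0% with an expected range from 0% to 5% in this measurement.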

Compound 3, percent of the compound remaining: 24%
The estimate for compound 3 lay 24 percentage points below the measured number, outside the stated range (above it).
By their numbers in this assay, from the lowest: compounds 1 and 2 (each within the scatter of the next); then compound 3.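

In this assay, for the compounds shown here, isopropoxy in place of tert-butyl on a carbonyl carbon gives a number 24 percentage points higher from compound 2 to compound 3 (beyond the scatter), the first change to lift the read-out clear of the scatter. Methyl in place of hydrogen on a saturated chain carbon bound to two oxygens next to a carbonyl group gives a number 24 percentage points higher from compound 1 to compound 3 (beyond the scatter), so the chain carbon is a second place where a single change moves the number. Compound 3 carries both the isopropoxy and the methyl, each of its two neighbours lacks one of them, and nothing at hand explains either step.

Going by these compounds, whether ethoxy or a longer chain on that carbonyl carbon, or ethyl on the chain carbon, would leave more compound intact stays open. With compound 2 at 0%, any difference hidden at the bottom of the read-out also remains unseen.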